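The source may report more compounds than this note shows. Statements on the series, on what has been measured and on what is new or still open speak of the compounds shown alone.

Compound 1 `CC(C)(C)OC(=O)NC[C@H]1CC[C@H](CNC(=O)c2cc(-c3cn[nH]c3)nc3ccccc23)CC1`: 3.5
Compound 2 `CC(C)(C)OC(=O)NC[C@H]1CC[C@H](CNC(=O)c2ccnc(-c3ccccc3)c2)CC1`: 4.7

Within the data shown here, in a physicochemical assay for lipophilicity (on this read-out higher numbers stand for higher lipophilicity and lower numbers for lower lipophilicity), compound 1 gives 3.5, the lower of the two numbers measured so far; compound 2 gives 4.7, a gap beyond the usual scatter. Compound 3 `CC(C)(C)OC(=O)NC[C@H]1CC[C@H](CNC(=O)c2cc(N3CCC(CCO)CC3)nc3ccccc23)CC1` is not yet measured. It differs from compound 1 in one place: 4-(2-hydroxyethyl)piperidin-1-yl in place of 1H-pyrazol-4-yl on an aromatic carbon. Among the measured compounds shown here, no pair of measured compounds covers this change, so its size is open. A rise in this assay beyond the scatter is expected, the estimated step being a number 0.80 log units higher from compound 1 to compound 3 (beyond the scatter). Compound 3 is therefore expected at 4.3, with a range of 3.6 to 5.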

Compound 3, distribution coefficient: 4.5
Estimate against measurement, compound 3: 0.20 log units below; the measured number falls inside the stated range.
By their numbers in this assay, from the lowest: compound 1; then compounds 3 and 2 (each within the scatter of the next).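

Among these compounds, on an aromatic carbon next to the ring nitrogen, 4-(2-hydroxyethyl)piperidin-1-yl in place of 1H-pyrazol-4-yl gives, in this assay, a number 1.00 log units higher from compound 1 to compound 3 (beyond the scatter), the first single-place step for this position. Both groups carry one hydrogen-bond donor and no net charge, so the step comes without a change in either count. No supporting measurement bears on the origin of this step.

As far as these compounds go, whether the rise belongs to the piperidine ring or to its 2-hydroxyethyl chain remains open. An unsubstituted piperidin-1-yl or a 2-aminoethyl chain on the ring would separate the two.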